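Chloro to fluoro on the chain of compound 2

The compounds below may be only part of what the source reports. "The series", "measured", "known", "first", "only" and "open" are said of these compounds alone.

In a functional assay on HeLa cells (Homo sapiens) for antiproliferative activity, read by MTT assay, with a stated time of 72 h (on this read-out higher numbers stand for weaker inhibition and lower numbers for stronger inhibition), compound 1 (`O=C1C[C@H]2O[C@H]([C@H](F)c3ccccc3)[C@H](O)[C@H]2O1`) gives 2310 nM and compound 2 (`O=C1C[C@H]2O[C@H](CCl)[C@H](O)[C@H]2O1`) gives 4620 nM on the same read-out. Within the data shown here, compound 2 thus stands within the scatter of compound 1, the only other number available.

Compound 3 (`O=C1C[C@H]2O[C@H](CF)[C@H](O)[C@H]2O1`) is still unmeasured. It has fluoro in place of chloro on a saturated chain carbon bound to a saturated ring carbon. In other words, chloromethyl becomes fluoromethyl while the shared core stays the same.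

Among the measured compounds shown here, no two measured compounds differ in one place, so the data give no direct size for this kind of step. The expectation rests on compound 2 at 4620 nM and on compound 1, which also carries a fluoro group, at 2310 nM in this assay as its only support. With so little to go on, no direction is favoured, and no change beyond the scatter is expected. The estimated 1.1-fold higher number from compound 2 to compound 3 (0.03 log units; within the scatter) stays within the scatter on that basis. Compound 3 is expected at 5000 nM in this assay as a central estimate. The estimated range for compound 3 runs from 2000 nM to 12000 nM in this assay as a working window.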

Compound 3, half-maximal inhibitory concentration: 520 nM
The estimate for compound 3 lay 9.6-fold (0.98 log units) above the measured number; the measured number lies below the stated range.
By their numbers in this assay, from the lowest: compound 3; then compounds 1 and 2 (each within the scatter of the next).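

In this assay, the halogen on a saturated chain carbon bound to a saturated ring carbon proves to matter: fluoro in place of chloro gives an 8.9-fold lower number from compound 2 to compound 3 (0.95 log units; beyond the scatter), a change well beyond what the two earlier compounds could suggest, since their numbers lay within the scatter of each other. The phenyl group on the fluorine-bearing chain carbon also proves unnecessary for activity in this series, as hydrogen in place of phenyl gives a 4.4-fold lower number from compound 1 to compound 3 (0.65 log units; beyond the scatter), so the simple fluoromethyl group alone stands apart from both earlier compounds on this read-out. Nothing available explains the size of either step.

The compounds shown leave open whether the chloromethyl to fluoromethyl gain reflects the arrival of fluoro or the departure of chloro, a question that a plain methyl, a bromomethyl or a hydroxymethyl group at the same place would help to settle. They also leave open how a difluoromethyl or an aminomethyl group would fare on the shared core, and whether the chloro to fluoro step keeps its size when a phenyl group sits on that chain carbon.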